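Working notes on cytotoxicity in a small series

A few compounds are considered here, and "the series" means these few. Any claim that something is new, unique, unknown or untested is made for them only; others in the source may bear on it.

Measured so far:
compound 1, `COc1ccc(CCCc2ccc(OC)c(OC)c2OC)c(O)c1`: 95.5%
compound 2, `COc1ccc(C(=O)CCc2ccc(OC)c(OC)c2)c(O)c1`: 89%
compound 3, `COc1ccc(C(=O)CCc2ccc(OC)c(OC)c2OC)c(O)c1`: 94.4%

In an ADME assay on RAW264.7 cells (Mus musculus) for cytotoxicity, read by MTT assay, with a stated time of 24 h, tested at 2.5 ug/mL (on this read-out higher numbers stand for a weaker effect at the one concentration tested and lower numbers for a stronger effect), compound 1 gives 95.5%, compound 3 gives 94.4% and compound 2 gives 89%. For the measured compounds named here, all three numbers lie within the scatter of one another, so no compound can be set apart from the others on this read-out.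

Going by the values given here, the one counted step among the measured compounds runs from compound 3 to compound 2: hydrogen in place of methoxy on an aromatic carbon. In this assay this gives a number 5.4 percentage points lower from compound 3 to compound 2 (within the scatter).

Compound 4, `COc1ccc(CCCc2cccc(OC)c2OC)c(O)c1`, has not yet been run in this assay. It stands to compound 1 as compound 2 stands to compound 3: hydrogen in place of methoxy on an aromatic carbon. The two changes are the same kind of change, not the same: in the step from compound 3 to compound 2 the place is ortho to a large group, whereas from compound 1 to compound 4 it is para to a large group. The difference between the core of compound 1 and the core of compound 3 is not broken down here.

The expectation for compound 4 rests on the step already seen, a number 5.4 percentage points lower from compound 3 to compound 2 (within the scatter), which was within the scatter, and on the starting value of compound 1, 95.5%. The step from compound 1 to compound 4 in this assay is therefore expected to be small, about a number 4.5 percentage points lower from compound 1 to compound 4 (within the scatter). Compound 4 is estimated at 91% in this assay, with a likely range from 80% to 100%.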

Compound 4, a percentage reported as activity, at one concentration (the size of the read-out at that concentration, not a potency): 99%
Compound 4: middle estimate off by 8 percentage points, on the low side; the measured number falls inside the stated range.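

In this assay, putting hydrogen in place of methoxy on an aromatic carbon gives a number 3.5 percentage points higher from compound 1 to compound 4 (within the scatter). Set beside the earlier step, this one shows no difference in how the change reads out on the two cores, and neither step can be told from repeated measurement: the same change on two cores in this assay, a number 5.4 percentage points lower (within the scatter) from compound 3 to compound 2 and a number 3.5 percentage points higher (within the scatter) from compound 1 to compound 4, 8.9 percentage points apart, within the scatter of two such steps This supports only a limited statement: on these two cores, at the one concentration tested, the change gives no readable shift in either direction, but it does not show that the change is without effect in general, that the two cores respond alike at other concentrations, or that the place of the change is of no importance, since that place is not the same on the two cores.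

The compounds shown leave open how this read-out responds when something other than methoxy or hydrogen stands at that place, such as an amine or a carboxylic acid, or when a longer chain joins the two rings. With every number taken at a single concentration, it also stays open whether any difference among these compounds would appear at a higher concentration.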